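The source may report more compounds than this note shows. Statements on the series, on what has been measured and on what is new or still open speak of the compounds shown alone.

Compound 1 `CC(C)c1n[nH]c2c(NCc3ccc(-c4ccccn4)cc3)nc(SCCCN(C)C)nc12` stands at the lowest number among the three measured compounds in a functional assay on HT cells (Homo sapiens) for antiproliferative activity, read by fluorescence, with a stated time of 72 h (a higher number here means a weaker inhibitor of growth, a lower number a stronger inhibitor of growth), where compound 1 gives 105 nM. Compound 2 `CC(C)c1n[nH]c2c(NCc3ccc(-c4ccccn4)cc3)nc(SC3CCCCC3O)nc12` gives 636 nM in this assay, and compound 3 `C=CCSc1nc(NCc2ccc(-c3ccccn3)cc2)c2[nH]nc(C(C)C)c2n1` gives 1010 nM. Both neighbours lie beyond the scatter from compound 1: the step of a 6.1-fold higher number from compound 1 to compound 2 (0.78 log units; beyond the scatter), and the step of a 9.6-fold higher number from compound 1 to compound 3 (0.98 log units; beyond the scatter). Compound 4 `COCSc1nc(NCc2ccc(-c3ccccn3)cc2)c2[nH]nc(C(C)C)c2n1` differs from compound 1 at the same place as compound 3 does: methoxy in place of 2-(dimethylamino)ethyl on a saturated chain carbon bound to a sulfur. The two measured steps that bear on it both remove the 2-(dimethylamino)ethyl chain, or the 3-(dimethylamino)propyl group as a whole, and both raise the number in this assay by a modest but clear amount. A step of similar size, in the same direction, is therefore expected here. The step expected for compound 4 is a 6.7-fold higher number from compound 1 to compound 4 (0.82 log units; beyond the scatter). Compound 4 is thus estimated to give 700 nM in this assay, within a range from 250 nM to 2000 nM.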

Compound 4, concentration for 50% growth inhibition: 340 nM
For compound 4 the middle estimate is 2.1-fold (0.31 log units) above the measured one; the range from low to high includes it.
By their numbers in this assay, from the lowest: compound 1; then compounds 4, 2 and 3 (each within the scatter of the next, the first and the last beyond it).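

Compound 4 shows that two chains on the sulfur that both lack the dimethylamino group can still differ: methoxy in place of vinyl on the saturated chain carbon gives a 3.0-fold lower number from compound 3 to compound 4 (0.47 log units; beyond the scatter) in this assay and so separates them. Against compound 1 the change still gives a 3.2-fold higher number from compound 1 to compound 4 (0.51 log units; beyond the scatter) and leaves compound 1 with the lowest number of the four. The methoxymethyl and 2-hydroxycyclohexyl groups on the sulfur cannot be told apart, as a 1.9-fold lower number from compound 2 to compound 4 (0.27 log units; within the scatter) shows for this pair.

Nothing shown gives a reason for these differences. On these data alone, whether a chain as long as 3-(dimethylamino)propyl but ending in a methoxy group, a hydroxyl group or a morpholine would close the remaining gap to compound 1 stays open.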